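A few compounds are considered here, and "the series" means these few. Any claim that something is new, unique, unknown or untested is made for them only; others in the source may bear on it.

Compound 1 `CNC(=O)/C=C1/COc2cc(OS(=O)(=O)c3ccccc3)ccc21` gives 34 nM in an assay (strain Sprague-Dawley) for inhibition of Amine oxidase [flavin-containing] A (Rattus norvegicus), read by spectrophotometry, with a stated time of 5 min; a lower number here means a stronger inhibitor, a higher number a weaker inhibitor.
Compound 2 `CNC(=O)/C=C1/COc2cc(OS(=O)(=O)c3cccc(F)c3)ccc21` gives 41 nM in this assay.
Compound 3 `CNC(=O)/C=C1/COc2cc(OS(=O)(=O)c3ccc([N+](=O)[O-])cc3)ccc21` gives 37 nM in this assay.

Compound 1 stands at the lowest of the three numbers, but the other two sit within the usual scatter of it: a 1.2-fold higher number from compound 1 to compound 2 (0.08 log units; within the scatter) and a 1.1-fold higher number from compound 1 to compound 3 (0.04 log units; within the scatter). Compound 4 `CNC(=O)/C=C1/COc2cc(OS(=O)(=O)c3ccc(C(C)=O)cc3)ccc21` shares the core of compound 1 and differs from it in one place: acetyl in place of hydrogen on an aromatic carbon.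

Among the compounds with values here, two measured steps bear on this change, since each also places a new group on the same six-membered aromatic ring of carbon only and leaves the rest of the molecule untouched. The fluoro step, a 1.2-fold higher number from compound 1 to compound 2 (0.08 log units; within the scatter), and the nitro step, a 1.1-fold higher number from compound 1 to compound 3 (0.04 log units; within the scatter), both stayed within the scatter, and the exchange between those two groups, a 1.1-fold lower number from compound 2 to compound 3 (0.04 log units; within the scatter), did the same. Within the data shown here, nothing among the measured compounds suggests that the sulfonyl-bound ring is sensitive to what is placed on it, so in this assay no step beyond the scatter is expected for compound 4 in either direction.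

Compound 4 is therefore estimated at 38 nM, with a range from 18 nM to 80 nM. The expected step is a 1.1-fold higher number from compound 1 to compound 4 (0.05 log units; within the scatter).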

Compound 4, half-maximal inhibitory concentration: 29 nM
For compound 4 the middle estimate is 1.3-fold (0.12 log units) above the measured one; low and high end bracket the measured number.
By their numbers in this assay, from the lowest: compounds 4, 1, 3 and 2 (each within the scatter of the next).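

Acetyl adds a third group to those tried on this ring, and the number again stays close to that of the unsubstituted phenyl: in this assay, the change gives a 1.2-fold lower number from compound 1 to compound 4 (0.07 log units; within the scatter). The exchanges with the earlier substituted rings also remain small, with a 1.3-fold lower number from compound 3 to compound 4 (0.11 log units; within the scatter) for acetyl in place of nitro at the same place on the ring and a 1.4-fold lower number from compound 2 to compound 4 (0.15 log units; within the scatter) for 4-acetylphenyl in place of 3-fluorophenyl, so among these four compounds, no change on this ring leaves the scatter, and none of them goes against this. No measurement shown here accounts for this tolerance or explains how the acetyl group is accommodated.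

Going by these compounds, whether this tolerance extends to a primary amine or a carboxylic acid on this ring, or to a longer chain in place of acetyl, remains open. The four compounds also share the same core, so they do not show how the number would respond to a change made there rather than on the sulfonyl-bound ring.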